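Replacing 4-fluorophenyl with 3-methoxyphenyl: compound 3 to compound 4

The source may report more compounds than this note shows. Statements on the series, on what has been measured and on what is new or still open speak of the compounds shown alone.

In a functional assay on the whole organism (strain Kunming) with Mus musculus as the target, with a stated time of 0.5 h (on this read-out lower numbers stand for an effect already at smaller amounts and higher numbers for an effect only at larger amounts of compound), compound 1 `COc1ccccc1/C=C/C(=O)OC/C=C/c1cc(OC)c(OC)cc1OC` gives 625 umol/kg, compound 2 `COc1cc(OC)c(OC)cc1/C=C/COC(=O)/C=C/c1ccccc1Cl` gives 385 umol/kg and compound 3 `COc1cc(OC)c(OC)cc1/C=C/COC(=O)/C=C/c1ccc(F)cc1` gives 449 umol/kg. Compound 3 therefore stands within the scatter of both others. Compound 4 `COc1cccc(/C=C/C(=O)OC/C=C/c2cc(OC)c(OC)cc2OC)c1` differs from it by 3-methoxyphenyl in place of 4-fluorophenyl on a double-bonded chain carbon bound to a double-bonded chain carbon, with 3-methoxyphenyl in place of 4-fluorophenyl on a double-bonded chain carbon bound to a double-bonded chain carbon. Among the measured compounds shown here, three measured steps bear on this: a 1.4-fold lower number from compound 1 to compound 3 (0.14 log units; within the scatter), a 1.2-fold higher number from compound 2 to compound 3 (0.07 log units; within the scatter) and a 1.6-fold lower number from compound 1 to compound 2 (0.21 log units; within the scatter). All three lie within the scatter, so no change beyond it is expected in this assay. The expected size is a 1.1-fold higher number from compound 3 to compound 4 (0.06 log units; within the scatter). For compound 4 the estimate is 510 umol/kg, with an expected range of 300 umol/kg to 870 umol/kg.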

Compound 4, dose for half-maximal effect: 643 umol/kg
Beside the measured number, compound 4's estimate is 1.3-fold (0.10 log units) below it; the range from low to high includes it.
By their numbers in this assay, from the lowest: compounds 2, 3, 1 and 4 (each within the scatter of the next).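

In this assay the 3-methoxyphenyl group on a double-bonded chain carbon bound to a double-bonded chain carbon gives a 1.4-fold higher number from compound 3 to compound 4 (0.16 log units; within the scatter) and a 1.7-fold higher number from compound 2 to compound 4 (0.22 log units; within the scatter) and a 1.0-fold higher number from compound 1 to compound 4 (0.01 log units; within the scatter) and so stays within the scatter of all three earlier groups. Thus 2-methoxyphenyl, 2-chlorophenyl, 4-fluorophenyl and 3-methoxyphenyl at this place cannot be told apart on this read-out. Nothing available here offers an explanation for this result. As far as these compounds go, whether an amine, a carboxylic acid or a longer chain at this place would give a step beyond the scatter remains open.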